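This account rests on a few compounds, and the source may have more. Where it says the series, first, only, none or still open, it means among the compounds named here.

Working notes on the series.

Compound 1 `COc1ccc(Cl)cc1C(=O)NCCC1CCN(S(=O)(=O)NC(=O)NC2CCCCC2)CC1` and compound 2 `COc1ccc(Cl)cc1C(=O)NCCC1CCN(S(=O)(=O)NC(=O)NC[C@H]2C[C@@H]3CC[C@@H]2O3)CC1` share one core and differ only in the ring carried on the amide-type nitrogen of the urea. For the measured compounds named here, in a functional assay on the whole organism (blood) with Rattus norvegicus as the target, with stated times of 24 h and 1 h, at a dose of 5 mg/kg by the intraperitoneal route (a lower number here means a weaker effect, a higher number a stronger effect of the compound at the dose given), compound 1 gives 25% and compound 2 gives 27%; the two numbers sit within the scatter of each other, so neither compound is set apart, and the step of a number 2 percentage points higher from compound 1 to compound 2 (within the scatter) is the only change measured so far at that position.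

Compound 3 `COc1ccc(Cl)cc1C(=O)NCCC1CCN(S(=O)(=O)NC(=O)NN2CCCCCC2)CC1` is not yet measured. It keeps the whole core of compound 2 and changes the same position: a group of 7 heavy atoms (6 carbon, 1 nitrogen; one seven-membered non-aromatic ring with 1 hetero atom) in place of a group of 8 heavy atoms (7 carbon, 1 oxygen; 2 five-membered non-aromatic rings with 1 hetero atom each), on an amide-type nitrogen. Going by the values given here, the one step that bears on this change is the ring swap on the same nitrogen, a number 2 percentage points higher from compound 1 to compound 2 (within the scatter), which stayed within the scatter; no other pair in the set touches that position. On that basis the expected step of a number 1 percentage points lower from compound 2 to compound 3 (within the scatter) is none beyond the scatter. For compound 3 the estimate in this assay is 26%, with a range from 12% to 40%, and a small chance that only a limit is reported.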

Compound 3, a percentage reported as activity, at one dose (the size of the read-out at that dose, not a potency): 36%
Compound 3: the middle estimate sits 10 percentage points below what was measured; the range from low to high includes it.
By their numbers in this assay, from the lowest: compounds 1, 2 and 3 (each within the scatter of the next, the first and the last beyond it).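

In this assay this position now shows its first change beyond the scatter: a number 11 percentage points higher from compound 1 to compound 3 (beyond the scatter) with azepan-1-yl in place of cyclohexyl on the amide-type nitrogen. Measured against the group with two five-membered rings, the same azepan-1-yl group gives a number 9 percentage points higher from compound 2 to compound 3 (within the scatter) and so does not set compound 3 apart from compound 2. The position is therefore not shown to be indifferent to the group it carries, but the separation is modest and holds only for the pair with cyclohexyl, while compound 2 remains within the scatter of both other compounds.

The compounds shown do not separate the effect of ring size from that of the ring nitrogen on this position, so a piperidin-1-yl or cycloheptyl group on the same nitrogen, or an open-chain amine such as diethylamino, would be needed to tell these apart. No measurement to hand speaks to what lies behind the step from cyclohexyl to azepan-1-yl.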